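Benzyl in Place of Methyl on the Amine

A few compounds are considered here, and "the series" means these few. Any claim that something is new, unique, unknown or untested is made for them only; others in the source may bear on it.

Compound 3 `CN(C)Cc1nc2ccccc2c(-c2ccccc2)c1C(=O)NCc1cc(C(F)(F)F)cc(C(F)(F)F)c1` gives 0.22 nM in an in vitro assay on UC11MG cells for binding affinity to Substance-P receptor (Homo sapiens), read by radioligand binding; a lower number here means a stronger inhibitor, a higher number a weaker inhibitor. Within the data shown here, of the three compounds measured so far, compound 3 stands second: compound 2 `O=C(NCc1cc(C(F)(F)F)cc(C(F)(F)F)c1)c1c(CBr)nc2ccccc2c1-c1ccccc1` gives 0.01 nM, while compound 1 `O=C(NCc1cc(C(F)(F)F)cc(C(F)(F)F)c1)c1c(CCl)nc2ccccc2c1-c1ccccc1` gives 26 nM. The steps of a 2600-fold lower number from compound 1 to compound 2 (3.41 log units; beyond the scatter), a 120-fold lower number from compound 1 to compound 3 (2.07 log units; beyond the scatter) and a 22-fold higher number from compound 2 to compound 3 (1.34 log units; beyond the scatter) show that exchanging the group on this saturated chain carbon moves this assay a great deal. Compound 4 `CN(Cc1ccccc1)Cc1nc2ccccc2c(-c2ccccc2)c1C(=O)NCc1cc(C(F)(F)F)cc(C(F)(F)F)c1` differs from compound 3 by phenyl in place of hydrogen on a saturated chain carbon bound to an amine nitrogen. Among the measured compounds shown here, no measured step alters the substituents on the amine nitrogen itself, so none bears directly on this change; the large swings nearby are the only guide. A modest step of a 2.7-fold higher number from compound 3 to compound 4 (0.44 log units; beyond the scatter) is expected, with a higher number judged somewhat more likely than a lower one. Compound 4 is estimated at 0.6 nM, within 0.05 nM to 6 nM.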

Compound 4, half-maximal inhibitory concentration: 180 nM
For compound 4 the middle estimate is 300-fold (2.48 log units) below the measured one, and the stated range ends below it.
By their numbers in this assay, from the lowest: compound 2; then compound 3; then compound 1; then compound 4.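

In this assay there is an 820-fold higher number from compound 3 to compound 4 (2.91 log units; beyond the scatter) when benzyl takes the place of methyl, so the group on this amine nitrogen matters greatly, not just the presence of an amine. Amines are not interchangeable here: dimethylamino in place of chloro lowered the number, whereas benzyl(methyl)amino gives a 6.9-fold higher number from compound 1 to compound 4 (0.84 log units; beyond the scatter) in the same exchange. Against bromo, it gives an 18000-fold higher number from compound 2 to compound 4 (4.26 log units; beyond the scatter) as the largest step so far.

As far as these compounds go, whether ethyl on the amine, or a ring amine such as piperidine, would fare like methyl or like benzyl remains open. Nothing available explains this loss.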